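Series notes: from compound 3 to compound 4

The source may hold more compounds than are shown below. What is called first, only, known or untested is meant among the compounds shown, and "the series" means these compounds.

Compound 1 `O=C(N/N=C/c1ccc(O)c(O)c1)c1ccc(-c2nc3ccccc3s2)cc1` gives 15100 nM in an assay on isolated protein for inhibition of Maltase-glucoamylase (Homo sapiens), with a stated time of 15 min; on this read-out higher numbers stand for weaker inhibition and lower numbers for stronger inhibition. Compound 2 `O=C(N/N=C/c1ccc(F)c(Br)c1)c1ccc(-c2nc3ccccc3s2)cc1` gives 28000 nM in this assay, and compound 3 `COc1ccc(/C=N/NC(=O)c2ccc(-c3nc4ccccc4s3)cc2)cc1` gives 18300 nM. On these three numbers compound 3 stands second highest, with compound 1 nearest and compound 2 furthest, yet all three lie within the scatter of one another, so no real order among them can be read.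

Compound 4 `O=C(N/N=C/c1ccncc1)c1ccc(-c2nc3ccccc3s2)cc1` is not yet measured. It differs from compound 3 by pyridin-4-yl in place of 4-methoxyphenyl on a carbon with a double bond to nitrogen. The measured steps that bear on this change are those at the same carbon: a 1.2-fold higher number from compound 1 to compound 3 (0.08 log units; within the scatter) and a 1.5-fold lower number from compound 2 to compound 3 (0.18 log units; within the scatter). Both earlier swaps of the ring on that carbon left the number within the scatter, so a further swap to pyridin-4-yl is expected to do the same, with no step beyond the scatter in either direction. Compound 4 is therefore estimated at 18000 nM, with a range from 8000 nM to 40000 nM. The expected step is a 1.0-fold lower number from compound 3 to compound 4 (0.01 log units; within the scatter).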

Compound 4, half-maximal inhibitory concentration: "not active" (no number reported)
The entry for compound 4 holds no number; the estimate stays without a comparison.
By their numbers in this assay, from the lowest: compounds 1, 3 and 2 (each within the scatter of the next).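

Going by these compounds alone, compound 4 is reported as "not active" in this assay with no number, so no step linking it to compound 1, compound 2 or compound 3 can be read. Going by these compounds, how far pyridin-4-yl in place of 4-methoxyphenyl shifts inhibition stays open, and no evidence at hand bears on this result.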